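Oxan-4-yl for 4-methoxycyclohexyl: compound 3 ahead

A few compounds are considered here, and "the series" means these few. Any claim that something is new, unique, unknown or untested is made for them only; others in the source may bear on it.

Compound 1 `N#Cc1cnc(NCc2cnccc2C(F)(F)F)cc1N[C@H]1C[C@@H](O)C1` and compound 2 `CO[C@H]1CC[C@H](Nc2cc(NCc3cnccc3C(F)(F)F)ncc2C#N)CC1` share one core and differ only in the group carried on a nitrogen on an aromatic ring. In an assay on isolated protein for inhibition of protein kinase C delta type (Homo sapiens), read by TR-FRET, with a stated time of 2 h (on this read-out lower numbers stand for stronger inhibition and higher numbers for weaker inhibition), compound 1 gives no number but only a limit, > 10000 nM. In this assay compound 2 likewise gives only a limit, > 10000 nM. The step that the two limits leave unreadable from compound 1 to compound 2 is therefore unreadable, because both values sit at the limit (the limit of > 10000 nM in this assay, at which 2 of the 2 values shown sit). On the numbers shown, compound 2 stands at the assay limit, as does the only other measured compound.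

Compound 3 `N#Cc1cnc(NCc2cnccc2C(F)(F)F)cc1NC1CCOCC1` differs from compound 2 by oxan-4-yl in place of 4-methoxycyclohexyl on a nitrogen on an aromatic ring. Among the measured compounds shown here, the single measured step, from compound 1 to compound 2, touches the same position, but its size cannot be read, so no measured step gives a direction for the present change. With both measured compounds at the limit (the limit of > 10000 nM in this assay, at which 2 of the 2 values shown sit), the step that the limit leaves unreadable from compound 2 to compound 3 is expected to be none beyond the scatter. Compound 3 is estimated at 20000 nM, with a range from 8000 nM to 60000 nM, and most likely this assay will again report only a limit.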

Compound 3, half-maximal inhibitory concentration: 9800 nM
The estimate for compound 3 lay 2.0-fold (0.31 log units) above the measured number, within the range that was stated.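

In this assay, among the compounds shown here, compound 3 gives 9800 nM, the first actual number for any group on this nitrogen on an aromatic ring. The other values shown are limits: the limit of > 10000 nM in this assay, at which 2 of the 3 values shown sit. Oxan-4-yl in place of 4-methoxycyclohexyl gives an at least 1.0-fold lower number from compound 2 to compound 3 (0.00 log units; that floor lies within the scatter), and oxan-4-yl in place of 3-hydroxycyclobutyl gives an at least 1.0-fold lower number from compound 1 to compound 3 (0.00 log units; that floor lies within the scatter). These steps are floors that do not clear the scatter, so the result places a measurable number at this position but does not show that oxan-4-yl gives stronger inhibition than either earlier group; the step between the two limits still cannot be read.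

For the compounds shown here, the true size of both steps remains open, since the two earlier compounds carry limits rather than numbers, and the single number at this position cannot show a trend. Also open, from the compounds shown here alone, is whether a group of another kind on this nitrogen, such as a piperidin-4-yl with its ring amine, a cyclohexyl carrying a carboxylic acid, or a longer hydroxyalkyl chain, would move the number clearly beyond the scatter on the shared core.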